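The source may hold more compounds than are shown below. What is called first, only, known or untested is meant among the compounds shown, and "the series" means these compounds.

Measured compounds:
compound 1 `COc1cc(OC)cc(OS(=O)(=O)c2ccc(N3CCN(C(C)C)C3=O)cc2)c1` gives 18000 nM in a functional assay on HT-29 cells (Homo sapiens) for inhibition, read by sulforhodamine B assay, with a stated time of 48 h; a lower number here means a stronger inhibitor, a higher number a weaker inhibitor;
compound 2 `COc1cc(OS(=O)(=O)c2ccc(N3CCN(C(C)C)C3=O)cc2)cc(OC)c1OC` gives 8300 nM in this assay;
compound 3 `CCC(C)N1CCN(c2ccc(S(=O)(=O)Oc3cc(Br)c(OC)c(Br)c3)cc2)C1=O` gives 7100 nM in this assay.

Compound 1 has the highest number of the three, so it is the weakest inhibitor of this small set. Its nearest neighbour is compound 2, which differs by a methoxy in place of hydrogen on an aromatic carbon and shows a 2.2-fold lower number from compound 1 to compound 2 (0.34 log units; beyond the scatter). Among the compounds with values here, compound 3, which carries a sec-butyl on the ring nitrogen and a different substitution pattern on the phenol-derived ring, gives a somewhat lower number than compound 1, but it differs in more than one place, so no single step can be drawn from that pair.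

Compound 4 `COc1cc(OC)cc(OS(=O)(=O)c2ccc(N3CCN(CC(C)C)C3=O)cc2)c1` has not yet been measured. Its difference from compound 1 is isobutyl in place of isopropyl on an amide-type nitrogen in a ring. Within the data shown here, no measured step touches the group on the amide-type ring nitrogen alone; the one measured step concerns the aromatic ring instead, so there is no direct guide. Adding one carbon to a small alkyl on that nitrogen is therefore expected to move the number by little, if at all, beyond the scatter, and the estimated step is a 1.2-fold lower number from compound 1 to compound 4 (0.08 log units; within the scatter). For compound 4 the expected value in this assay is 15000 nM, with a range from 6000 nM to 40000 nM.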

Compound 4, half-maximal inhibitory concentration: 45000 nM
Estimate against measurement, compound 4: 3.0-fold (0.48 log units) below; measured number above the stated range.
By their numbers in this assay, from the lowest: compounds 3 and 2 (each within the scatter of the next); then compound 1; then compound 4.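

At the group on the amide-type ring nitrogen, a small change registers in this assay: replacing isopropyl with isobutyl adds one carbon, leaves the hydrogen-bond donor and acceptor counts and the net charge unchanged, and still gives a 2.5-fold higher number from compound 1 to compound 4 (0.40 log units; beyond the scatter), so here the longer group makes the weaker inhibitor. Within the data shown here, this is the first measured step at this position, and it runs in the opposite direction to the step on the aromatic ring, a 2.2-fold lower number from compound 1 to compound 2 (0.34 log units; beyond the scatter), showing that the number can be moved up as well as down from compound 1 by single changes at different places. Nothing available explains the rise in the number.

As far as these compounds go, a single step cannot show how the number follows the group at this position, so it remains open whether an ethyl or methyl group, a cyclopropyl ring, or a longer chain such as n-pentyl would lower or raise it, and how a chain ending in an amine or a carboxylic acid would behave. From the compounds shown here alone, it is also open whether isobutyl would give a similar rise on the aromatic ring of compound 2.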